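The compounds below may be only part of what the source reports. "The series", "measured", "known", "first", "only" and "open" are said of these compounds alone.

Measured in a physicochemical assay for solubility, with a stated time of 4 h, at pH 2.0; on this read-out lower numbers stand for lower solubility and higher numbers for higher solubility:
- compound 1 `CC(=O)CCc1cc(C)c(Oc2cc(Nc3ccc(C#N)cc3)c(N)cc2C(F)(F)F)c(C)c1`: 0.28 ug/mL
- compound 2 `CNC(=O)c1cc(N)c(Nc2ccc(C#N)cc2)cc1Oc1c(C)cc(CCC#N)cc1C`: 44.7 ug/mL
- compound 3 `Cc1cc(CCC#N)cc(C)c1Oc1cc(Nc2ccc(C#N)cc2)c(N)cc1CO`: 89.8 ug/mL

In this assay compound 1 has the lowest number of the three, beyond the scatter from both compound 2 and compound 3. Compound 4 `Cc1cc(/C=C/C#N)cc(C)c1Oc1cc(Nc2ccc(C#N)cc2)c(N)cc1C(F)(F)F` differs from compound 1 in one place: 2-cyanoethenyl in place of 2-acetylethyl on an aromatic carbon. That is, 2-cyanoethenyl stands in place of 2-acetylethyl on an aromatic carbon, meta to two methyl groups and para to a large group.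

Among the compounds with values here, only one measured step exists, a 2.0-fold higher number from compound 2 to compound 3 (0.30 log units; within the scatter), and it lies within the scatter. It is a different exchange, hydroxymethyl in place of methylcarbamoyl, so it bears on this change only indirectly. Within the data shown here, no measured step exchanges these two chains, and compound 1 differs from compound 2 and compound 3 in more than one place. No step beyond the scatter is therefore expected in this assay, and the data give no direction. The estimated step is a 1.1-fold higher number from compound 1 to compound 4 (0.03 log units; within the scatter). For compound 4 the expected value is 0.3 ug/mL, with an estimated range from 0.08 ug/mL to 1.5 ug/mL.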

Compound 4, solubility: 0.42 ug/mL
Estimate against measurement, compound 4: 1.4-fold (0.15 log units) below, and the stated range covers the measured number.
By their numbers in this assay, from the lowest: compounds 1 and 4 (each within the scatter of the next); then compounds 2 and 3 (each within the scatter of the next).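

In this assay, placing 2-cyanoethenyl in place of 2-acetylethyl on the aromatic carbon meta to two methyl groups gives a 1.5-fold higher number from compound 1 to compound 4 (0.18 log units; within the scatter). Within the data shown here, this is the first measured step at this position, and it shows that this read-out does not separate the two chains on the core of compound 1, although one carries a nitrile and the other a carbonyl. No measurement at hand bears on why the two chains read alike.

From the compounds shown here alone, it remains open whether a chain ending in an amine or a carboxylic acid at this position would give a step beyond the scatter in this assay. Also open, going by these compounds, is whether this exchange would read the same on a core carrying hydroxymethyl or methylcarbamoyl instead of trifluoromethyl.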